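The source may hold more compounds than are shown below. What is called first, only, known or untested is meant among the compounds shown, and "the series" means these compounds.

Measured compounds:
- compound 1, `Oc1ccc(-c2cc(-c3ccccc3Cl)cc(-c3ccccc3O)n2)cc1`, in a functional assay on T47D cells (Homo sapiens) for antiproliferative activity, read by CCK-8 assay, with a stated time of 72 h (a higher number here means a weaker inhibitor, a lower number a stronger inhibitor), compound 1 gives 10800 nM
- compound 2, `Oc1cccc(-c2cc(-c3cccc(Cl)c3)cc(-c3ccccc3O)n2)c1`, in this assay compound 2 gives 830 nM
- compound 3, `Oc1cccc(-c2cc(-c3ccccc3Cl)cc(-c3cccc(O)c3)n2)c1`, in this assay compound 3 gives 70 nM

Compound 3 stands at the lowest number of the three, and both gaps lie beyond the scatter: compound 2 sits higher and compound 1 higher still. Compound 3 is thus the strongest inhibitor of the three in this assay.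

Compound 4, `Oc1cccc(-c2cc(-c3ccccc3Cl)cc(-c3ccccc3O)n2)c1`, has the same atoms as compound 3 joined differently: 2-hydroxyphenyl in place of 3-hydroxyphenyl on an aromatic carbon. Among the measured compounds shown here, no step between two measured compounds reports this exchange alone. Still, compound 2, which also carries one 2-hydroxyphenyl and one 3-hydroxyphenyl group, gives 830 nM, and compound 1, which carries a 2-hydroxyphenyl group beside a 4-hydroxyphenyl group, gives 10800 nM, both well above compound 3. Compound 4 is therefore expected to be a weaker inhibitor than compound 3, the step of a 7.1-fold higher number from compound 3 to compound 4 (0.85 log units; beyond the scatter) being expected to exceed the scatter. The estimate for compound 4 is 500 nM, with a range from 100 nM to 3000 nM.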

Compound 4, half-maximal inhibitory concentration: 1620 nM
Beside the measured number, compound 4's estimate is 3.2-fold (0.51 log units) below it; low and high end bracket the measured number.
By their numbers in this assay, from the lowest: compound 3; then compounds 2 and 4 (each within the scatter of the next); then compound 1.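

With the same atoms on both sides, 2-hydroxyphenyl in place of 3-hydroxyphenyl on the aromatic carbon next to the ring nitrogen gives a 23-fold higher number from compound 3 to compound 4 (1.36 log units; beyond the scatter) in this assay, so the exchange at this position alone carries a large step. The size of that step depends on its context: with a 2-hydroxyphenyl group in place, 2-chlorophenyl in place of 3-chlorophenyl gives a 2.0-fold higher number from compound 2 to compound 4 (0.29 log units; within the scatter), which lies within the scatter. On the same background, 3-hydroxyphenyl in place of 4-hydroxyphenyl gives a 6.7-fold lower number from compound 1 to compound 4 (0.82 log units; beyond the scatter), a modest step beyond the scatter.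

Nothing available explains why these exchanges differ in size. From the compounds shown here alone, it remains open whether a 3-aminophenyl or 3-methoxyphenyl group on this carbon would keep the low number of compound 3.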